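From 4-Ethoxyphenyl to 2-Ethoxyphenyl on a Shared Core

A few compounds are considered here, and "the series" means these few. Any claim that something is new, unique, unknown or untested is made for them only; others in the source may bear on it.

In a functional assay on HeLa cells (Homo sapiens) for inhibition, read by sulforhodamine B assay (on this read-out lower numbers stand for stronger inhibition and higher numbers for weaker inhibition), compound 1 `O=C1C(Nc2ccc(I)cc2)=CC(=O)c2c1nc1n2[C@H]2OC[C@@H](O)[C@H]2OC1`, which carries 4-iodophenyl on an amine nitrogen, gives 4010 nM. Compound 2 `O=C1C(NC2CC2)=CC(=O)c2c1nc1n2[C@H]2OC[C@@H](O)[C@H]2OC1`, with cyclopropyl at that nitrogen, gives > 16000 nM, which is a limit of the assay and not a number. Compound 3 `CCOc1ccc(NC2=CC(=O)c3c(nc4n3[C@H]3OC[C@@H](O)[C@H]3OC4)C2=O)cc1`, with 4-ethoxyphenyl there, gives 14400 nM, the higher of the two actual numbers in this small set.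

Compound 4 `CCOc1ccccc1NC1=CC(=O)c2c(nc3n2[C@H]2OC[C@@H](O)[C@H]2OC3)C1=O` has 2-ethoxyphenyl in place of 4-ethoxyphenyl on an amine nitrogen. The closest measured change, ethoxy in place of iodo, gave a 3.6-fold higher number from compound 1 to compound 3 (0.56 log units; beyond the scatter), which is beyond the scatter. Replacing the whole aryl group gave an at least 3.9-fold higher number from compound 1 to compound 2 (0.60 log units; beyond the scatter), also beyond the scatter, while the remaining comparison gave an at least 1.1-fold lower number from compound 2 to compound 3 (0.04 log units; that floor lies within the scatter), with a floor inside the scatter. None of these steps compares two placements of one group, so they suggest only that a shift in this assay would be modest, and they do not fix its direction. The expected result is therefore no clear shift beyond the scatter, with a 1.4-fold lower number from compound 3 to compound 4 (0.16 log units; within the scatter) as the estimated step. For compound 4 the estimated value is 10000 nM, within an expected range of 4500 nM to 16000 nM.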

Compound 4, half-maximal inhibitory concentration: 8300 nM
Estimate against measurement, compound 4: 1.2-fold (0.08 log units) above, and the stated range covers the measured number.
By their numbers in this assay, from the lowest: compound 1; then compounds 4 and 3 (each within the scatter of the next). At a limit, above all of these: compound 2.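

In this assay, among these compounds, the two ethoxy placements give the first direct comparison of one group at two places on the phenyl ring, and the result is a 1.7-fold lower number from compound 3 to compound 4 (0.24 log units; within the scatter). At this amine nitrogen, then, exchanging 4-ethoxyphenyl for 2-ethoxyphenyl does not carry the number beyond the scatter, so the placement of the ethoxy group has no clear effect in this set. The 4-iodophenyl group also stays apart from the new group, with a 2.1-fold higher number from compound 1 to compound 4 (0.32 log units; beyond the scatter), so the modest gap first seen with 4-ethoxyphenyl remains with 2-ethoxyphenyl, while the comparison with cyclopropyl, an at least 1.9-fold lower number from compound 2 to compound 4 (0.28 log units; that floor lies within the scatter), gives only a floor set by a limit of the assay and settles no order: the limit of > 16000 nM in this assay, at which 1 of the 4 values shown sits.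

The compounds shown leave open whether the modest gap belongs to iodo itself or would also appear with another halogen such as bromo or chloro on the phenyl ring. They also leave open how a methoxy group, a longer alkoxy chain, an amine or a carboxylic acid on that ring would compare on the shared core.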